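The compounds below may be only part of what the source reports. "The series", "measured", "known", "first", "only" and "open" are said of these compounds alone.

Measured so far:
Compound 1, `CCCCCCCC/C=C\CCCCCCC(=O)c1ncc(-c2ccoc2)o1`: 610 nM
Compound 2, `CCCCCCCCCCCCCC(=O)C(F)(F)F`: 490 nM

Of the compounds shown here, two have been measured in an assay on isolated protein for inhibition of Fatty-acid amide hydrolase 1 (Homo sapiens); a lower number here means a stronger inhibitor, a higher number a weaker inhibitor. Compound 1 gives 610 nM, and compound 2, built on a different core, gives 490 nM. The two numbers lie within the usual scatter of each other, so neither compound can be called the stronger inhibitor on these data alone.

Compound 3, `CCCCCCCC/C=C\CCCCCCC(=O)c1ncco1`, has not yet been measured. It differs from compound 1 in one place: hydrogen in place of furan-3-yl on an aromatic carbon. Among the compounds with values here, nothing in the measured pair tells how much the furan-3-yl contributes, since no comparable pair of measured compounds exists here. My expectation is that stripping this ring from the core of compound 1 leaves a weaker inhibitor, with the step of a 4.9-fold higher number from compound 1 to compound 3 (0.69 log units; beyond the scatter) expected to go beyond the scatter toward a higher number. For compound 3 the estimate in this assay is 3000 nM, with a likely range from 800 nM to 12000 nM.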

Compound 3, inhibition constant: 17 nM
For compound 3 the middle estimate is 180-fold (2.25 log units) above the measured one, and the stated range ends above it.
By their numbers in this assay, from the lowest: compound 3; then compounds 2 and 1 (each within the scatter of the next).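

Replacing furan-3-yl with hydrogen on the aromatic carbon next to the ring oxygen gives a 36-fold lower number from compound 1 to compound 3 (1.55 log units; beyond the scatter) in this assay and is a large change. At this position, then, the furan-3-yl ring is not needed for inhibition in this assay, and the core without it is the stronger inhibitor of the pair. Nothing available here accounts for the size of this step.

From the compounds shown here alone, with only furan-3-yl and hydrogen compared at this carbon, it remains open whether a methyl group, a carboxylic acid or a phenyl ring there would give a number close to that of compound 3 or close to that of compound 1. Going by these compounds, it is also open whether the same change would have a similar effect in a compound with a shorter chain on the carbonyl.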